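Dropping the Bromo Group: An Untested Analogue of Compound 1

This account rests on a few compounds, and the source may have more. Where it says the series, first, only, none or still open, it means among the compounds named here.

compound 1 `C=CCOc1cc(Br)ccc1C(=O)c1cccnc1` — > 100000 nM
compound 2 `O=C(c1cccnc1)c1cc(Cl)cc(Cl)c1O` — 28700 nM

In a functional assay on PC-3 cells (Homo sapiens) for cytotoxicity, read by sulforhodamine B assay, with a stated time of 48 h (a higher number here means a weaker inhibitor, a lower number a stronger inhibitor), compound 1 gives > 100000 nM, which is a limit of the assay and not a measured number. Compound 1 therefore stands at the limit of > 100000 nM in this assay, at which 1 of the 2 values shown sits. In this assay compound 2 gives 28700 nM. Going by the values given here, the two measured compounds differ in more than one place, so no step between them is set out here.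

Compound 3 `C=CCOc1ccccc1C(=O)c1cccnc1` differs from compound 1 in one place: hydrogen in place of bromo on an aromatic carbon. Among the compounds with values here, no measured step covers this change, so the expectation rests on compound 1 alone. The step that the limit leaves unreadable from compound 1 to compound 3 is expected to be none beyond the scatter, with compound 3 most likely remaining at a limit rather than a number. In this assay compound 3 is estimated at 130000 nM, in a range from 40000 nM to 500000 nM.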

Compound 3, half-maximal inhibitory concentration: 55000 nM
Compound 3: middle estimate off by 2.4-fold (0.37 log units), on the high side; the range from low to high includes it.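

In this assay compound 1 gives > 100000 nM, which is a limit of the assay and not a number. Going by these compounds alone, with hydrogen in place of bromo on the aromatic carbon meta to an allyloxy group and para to a group of 8 heavy atoms, the series gains a first measured number at this position, and the change gives an at least 1.8-fold lower number from compound 1 to compound 3 (0.25 log units; that floor lies within the scatter). The true size of this step remains unknown, and the printed floor cannot show a real gain, because the starting point is a limit: the limit of > 100000 nM in this assay, at which 1 of the 3 values shown sits.

The compounds shown leave open how far compound 1 really lies from compound 3. They also leave open whether an amine, a carboxylic acid or a longer chain at this position would move the number in this assay beyond the scatter.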